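This account rests on a few compounds, and the source may have more. Where it says the series, first, only, none or still open, it means among the compounds named here.

Of the compounds shown here, three sharing one core have been measured in a functional assay on HEK293T cells for agonist activity at histamine H2 receptor (Homo sapiens), read by beta-arrestin recruitment; on this read-out higher numbers stand for larger maximal responses and lower numbers for smaller maximal responses. Compound 1 `Cc1nc(N)sc1CCCN/C(N)=N/C(=O)N[C@H](C)c1ccccc1` gives 0.34. Compound 2 `CCCCCCNC(=O)/N=C(\N)NCCCc1sc(N)nc1C` gives 0.28. Compound 3 `Cc1nc(N)sc1CCCN/C(N)=N/C(=O)NCc1ccccc1` gives 0.33. Compound 3 therefore sits in the middle of the three numbers, but the gaps to both of its neighbours are small: the step a number 0.010 lower from compound 1 to compound 3 (within the scatter) and the step a number 0.050 higher from compound 2 to compound 3 (within the scatter) each lie within the scatter of repeated measurements, so the three compounds cannot be told apart on this read-out.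

Compound 4 `Cc1nc(N)sc1CCCN/C(N)=N/C(=O)Nc1ccccc1` has not yet been measured. It differs from compound 3 by phenyl in place of benzyl on an amide-type nitrogen. Two of the measured steps touch the same region of the molecule. The step a number 0.010 lower from compound 1 to compound 3 (within the scatter) removed a methyl from the carbon next to the amide-type nitrogen, and the step a number 0.050 higher from compound 2 to compound 3 (within the scatter) replaced pentyl with phenyl on that carbon; both were within the scatter. The change to compound 4 removes that carbon altogether, leaving the ring directly on the nitrogen. Going by the values given here, with nothing among the measured steps pointing to a shift beyond the scatter, compound 4 is expected to behave much like compound 3, and the step a number 0.010 lower from compound 3 to compound 4 (within the scatter) is estimated to stay within the scatter. Compound 4 is therefore estimated at 0.32, with a range from 0.2 to 0.45.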

Compound 4, intrinsic activity: the largest response reached, as a fraction of the reference agonist's: 0.25
For compound 4 the middle estimate is 0.070 above the measured one; the range from low to high includes it.
By their numbers in this assay, from the lowest: compounds 4, 2, 3 and 1 (each within the scatter of the next).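

In this assay, replacing benzyl with phenyl on the amide-type nitrogen gives a number 0.080 lower from compound 3 to compound 4 (within the scatter) and so adds a new kind of attachment to the series: the aromatic ring now sits directly on that nitrogen, with no saturated chain carbon in the way, and the response still cannot be told apart from that of compound 3. The comparisons with the other two compounds agree, with a number 0.030 lower from compound 2 to compound 4 (within the scatter) for phenyl in place of hexyl and a number 0.090 lower from compound 1 to compound 4 (within the scatter) for phenyl in place of 1-phenylethyl, so across these four compounds, the groups tried on this nitrogen leave the maximal response indistinguishable. Nothing available explains why the response stays so similar across these groups.

The compounds shown leave open whether a methoxy group or a chlorine atom on the phenyl ring, or an amine or a carboxylic acid at the end of a longer chain on the same nitrogen, would shift the response beyond the usual scatter. They also leave open whether these four compounds would remain alike on a different read-out.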